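This account rests on a few compounds, and the source may have more. Where it says the series, first, only, none or still open, it means among the compounds named here.

Measured compounds:
- compound 1, `CC(C)=CC(=O)NC(=N)NC(=O)C=C(C)C` — 60300 nM
- compound 2, `CC(C)=CCC/C(C)=C/CC/C(C)=C/C(=O)NC(=N)N` — 10000 nM
- compound 3, `C=C1CCCC(C)(C)[C@@H]1CC/C(C)=C/C(=O)NC(=N)NC(=O)C=C(C)C` — 18100 nM

These three were tested in a functional assay on Hs 683 cells (Homo sapiens) for inhibition, read by MTT assay, with a stated time of 72 h; a lower number here means a stronger inhibitor of growth, a higher number a weaker inhibitor of growth. Compound 2 has the lowest of the three numbers. Its gap to compound 3 is within the usual scatter, so the two cannot be told apart; its gap to compound 1 is beyond the scatter, so compound 2 is clearly a stronger growth inhibitor than compound 1.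

Compound 4, `CC(C)=CCC/C(C)=C/C(=O)NC(=N)N`, has not yet been measured in this assay. It differs from compound 2 in one place: hydrogen in place of 3-methylbut-2-en-1-yl on a saturated chain carbon bound to a double-bonded chain carbon. For the measured compounds named here, no pair of measured compounds shows this change, so its effect here is not known from the data. Since the chain of compound 2 is shortened by this change, the step of a 2.5-fold higher number from compound 2 to compound 4 (0.40 log units; beyond the scatter) is expected to be modest and in the direction of a higher number, probably beyond the scatter. Compound 4 is therefore estimated to give 25000 nM, with a range from 8000 nM to 80000 nM.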

Compound 4, concentration for 50% growth inhibition: 39400 nM
Estimate against measurement, compound 4: 1.6-fold (0.20 log units) below, and the stated range covers the measured number.
By their numbers in this assay, from the lowest: compounds 2 and 3 (each within the scatter of the next); then compounds 4 and 1 (each within the scatter of the next).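

In this assay, putting hydrogen in place of 3-methylbut-2-en-1-yl on a saturated chain carbon bound to a double-bonded chain carbon gives a 3.9-fold higher number from compound 2 to compound 4 (0.60 log units; beyond the scatter), and this step lies beyond the scatter. For the compounds shown here, this is the first single change that can be read in the set: the earlier compounds included no pair differing in one place, so none of their numbers could be tied to a particular group. It shows that the growth inhibition of compound 2 depends in part on the 3-methylbut-2-en-1-yl group, although no evidence at hand explains this step.

Going by these compounds, what remains open is whether a longer chain at this place would lower the number further or leave it unchanged. On these data alone, it is also open whether a smaller group such as methyl, or a ring such as phenyl, could stand in for 3-methylbut-2-en-1-yl here.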